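This account rests on a few compounds, and the source may have more. Where it says the series, first, only, none or still open, it means among the compounds named here.

Three compounds share one core and differ in the chain on the amide nitrogen or in the ring held by an aromatic nitrogen. Compound 1 `C/C=C/C(=O)Nc1cccc(Oc2nc(Nc3cccc(OC)c3)nc3c2CSCC3)c1` carries the shortest chain. In an ADME assay on L02 cells (Homo sapiens) for cytotoxicity, read by MTT assay, with a stated time of 72 h (a higher number here means a weaker inhibitor, a lower number a stronger inhibitor), compound 1 gives only a limit of > 50000 nM. Compound 2 `CC/C=C/C(=O)Nc1cccc(Oc2nc(Nc3cccc(OC)c3)nc3c2CSCC3)c1` carries methyl in place of hydrogen on a saturated chain carbon bound to a double-bonded chain carbon. In this assay compound 2 gives only a limit of > 50000 nM. Compound 3 `CC/C=C/C(=O)Nc1cccc(Oc2nc(Nc3ccc(OC)nc3)nc3c2CSCC3)c1` holds another ring on the aromatic nitrogen; the difference between the core of compound 1 and the core of compound 3 is not broken down here. In this assay compound 3 gives only a limit of > 50000 nM. The steps a step that the two limits leave unreadable from compound 1 to compound 2 and a step that the two limits leave unreadable from compound 2 to compound 3 stay unreadable because of the limit of > 50000 nM in this assay, at which 3 of the 3 values shown sit.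

Compound 4 `CCC/C=C/C(=O)Nc1cccc(Oc2nc(Nc3ccc(OC)nc3)nc3c2CSCC3)c1` carries methyl in place of hydrogen on a saturated chain carbon, two bonds along the chain from a double-bonded chain carbon, the same kind of change as methyl in place of hydrogen on a saturated chain carbon bound to a double-bonded chain carbon, though here the place lies two bonds along the chain from the double-bonded chain carbon rather than bound to it. The step that the limit leaves unreadable from compound 3 to compound 4 is only an expectation, since a step that the two limits leave unreadable from compound 1 to compound 2 gave no readable size. Compound 4 is therefore expected to sit near 60000 nM, most probably again as a limit, between 25000 nM and 150000 nM.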

Compound 4, half-maximal inhibitory concentration: > 50000 nM
Compound 4: no number, only a limit; the forecaster's own chance of this, stated with the estimate: 85%; the middle value lies beyond the limit too.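

Compound 3 and compound 4 both give only limits, so no size can be read for the step between them, because: the limit of > 50000 nM in this assay, at which 4 of the 4 values shown sit.

The compounds shown leave open whether changing the chain or the ring alters toxicity to these cells at all.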